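Removing the phenethylsulfanyl arm from compound 1

This account rests on a few compounds, and the source may have more. Where it says the series, first, only, none or still open, it means among the compounds named here.

Among the measured compounds shown here, compound 1 `Cc1cc(Nc2cc(-c3ccccc3)[nH]n2)n2nc(SCCc3ccccc3)nc2n1` gives the lowest number of the three measured members in a functional assay on MCF7 cells (Homo sapiens) for inhibition, read by MTT assay, with a stated time of 72 h (on this read-out lower numbers stand for stronger inhibition and higher numbers for weaker inhibition), at 2700 nM. Compound 2 `CCCCCc1c(C)nc2nc(SCc3ccc(Cl)cc3)nn2c1Nc1cc(-c2ccccc2)[nH]n1` gives 6390 nM in this assay, and compound 3 `Cc1nc2nc(SCc3ccc(Cl)cc3)nn2c(Nc2cc(-c3ccccc3)[nH]n2)c1C` gives 10600 nM. Compound 4 `Cc1cc(Nc2cc(-c3ccccc3)[nH]n2)n2ncnc2n1` differs from compound 1 in one place: hydrogen in place of phenethylsulfanyl on an aromatic carbon. For the measured compounds named here, the only measured single change, a 1.7-fold higher number from compound 2 to compound 3 (0.22 log units; within the scatter), trims a saturated chain on a ring carbon rather than removing a sulfanyl arm, so it bears on the present step only loosely. Since the phenethylsulfanyl group is a far larger loss than that butyl chain, the number is expected to rise, with a step of a 2.6-fold higher number from compound 1 to compound 4 (0.41 log units; beyond the scatter). Compound 4 is therefore estimated at 7000 nM, with a range from 2500 nM to 25000 nM.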

Compound 4, half-maximal inhibitory concentration: > 50000 nM
Compound 4 ended at the assay's limit; the forecaster's own chance of this, stated with the estimate: 15%; middle value at least 7.1-fold (0.85 log units) from the limit.
By their numbers in this assay, from the lowest: compound 1; then compounds 2 and 3 (each within the scatter of the next). At a limit, above all of these: compound 4.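

Among the compounds shown here, compounds 1, 2 and 3 all carry a sulfanyl arm on this aromatic carbon, so only this pair shows the position without one. Hydrogen in place of phenethylsulfanyl gives an at least 18-fold higher number from compound 1 to compound 4 (1.26 log units; beyond the scatter) in this assay, so in this pair the measured inhibition depends on the arm. The value of compound 4 is a limit and not a number, so the full size of the step stays unknown: the limit of > 50000 nM in this assay, at which 1 of the 4 values shown sits.

Which part of the arm counts remains open. A methylsulfanyl group, an all-carbon phenylbutyl chain or an amine on this carbon would separate the sulfur from the phenyl ring.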